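Working notes on a second methoxy step in a small series

The source may report more compounds than this note shows. Statements on the series, on what has been measured and on what is new or still open speak of the compounds shown alone.

Measured so far, in a functional assay on MOLT-4 cells (Homo sapiens) for antiproliferative activity, with a stated time of 48 h; a higher number here means a weaker inhibitor, a lower number a stronger inhibitor:
compound 1, `C=C(Br)C(=O)Nc1ccc(/C=C/C(=O)c2ccccc2)cc1`, gives 3100 nM.
compound 2, `C=C(Br)C(=O)Nc1ccc(/C=C/C(=O)c2cccc(OC)c2)cc1`, gives 850 nM.
compound 3, `C=C(Br)C(=O)Nc1ccc(C(=O)/C=C/c2cccc(OC)c2)cc1`, gives 1100 nM.

Compound 1 and compound 2 share one core and differ only in methoxy in place of hydrogen on an aromatic carbon. That single change made a clear step in this assay: a 3.6-fold lower number from compound 1 to compound 2 (0.56 log units; beyond the scatter).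

Compound 3 is built on a different core. How the core of compound 3 differs from the core of compound 1 is not broken down here. In this assay the value of compound 3 lies within the scatter of the value of compound 2, so the two cannot be put in order; against compound 1 the value of compound 3 is lower by an amount beyond the scatter.

Compound 4, `C=C(Br)C(=O)Nc1ccc(C(=O)/C=C/c2ccc(OC)c(OC)c2)cc1`, has not yet been measured. It differs from compound 3 in methoxy in place of hydrogen on an aromatic carbon. The surroundings of the entering group are not the same as in the step from compound 1 to compound 2: there the methoxy stood meta to a large group, here it enters ortho to a methoxy group and para to a large group. It is the same kind of change, not the same change.

For this assay a step of a 2.2-fold lower number from compound 3 to compound 4 (0.34 log units; beyond the scatter) is expected. This expectation rests on the earlier step of a 3.6-fold lower number from compound 1 to compound 2 (0.56 log units; beyond the scatter), tempered by the different place of the entering group, which leaves the size uncertain.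

Compound 4 is estimated at 500 nM, with a range from 150 nM to 1500 nM.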

Compound 4, half-maximal inhibitory concentration: 1800 nM
The estimate for compound 4 lay 3.6-fold (0.56 log units) below the measured number; measured number outside the range, above it.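

In this assay, methoxy in place of hydrogen on an aromatic carbon gave a 1.6-fold higher number from compound 3 to compound 4 (0.21 log units; within the scatter), so compound 3 and compound 4 cannot be put in order, and the clear step seen on the core of compound 1 did not carry over to the core of compound 3. The same change therefore cannot be assumed to give a step of the same size on both cores in this series: the same change on two cores in this assay, a 3.6-fold lower number (0.56 log units; beyond the scatter) from compound 1 to compound 2 and a 1.6-fold higher number (0.21 log units; within the scatter) from compound 3 to compound 4, 6.0-fold (0.78 log units) apart, beyond the scatter of two such steps

For the compounds shown here, this rests on one pair per core, and the core is not the only difference between the pairs, since in compound 4 the methoxy enters ortho to a methoxy group and para to a large group, so these data cannot separate the effect of the core from that of the place, nor do they show that methoxy is without effect on the core of compound 3 in general.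

On these data alone, it remains open whether a second methoxy on the core of compound 2 would behave as it does on the core of compound 3. As far as these compounds go, it also remains open whether a hydroxy group, a fluorine atom or an ethoxy group entering at the same carbon would follow the methoxy result on either core.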